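Methylsulfanyl in place of pyrrolidin-1-yl: cytotoxicity outlook

This account rests on a few compounds, and the source may have more. Where it says the series, first, only, none or still open, it means among the compounds named here.

In an ADME assay on MOLT-3 cells (Homo sapiens) for cytotoxicity, with a stated time of 7 days (on this read-out higher numbers stand for lower toxicity in this test and lower numbers for higher toxicity in this test), compound 3 (`Nc1nc(N2CCCC2)c2ncn(/C=C3/CC3(CO)CO)c2n1`) has no number: its entry reads "not determined" (no result reported) and offers no starting point. Compound 1 (`CC(C)CSc1nc(N)nc2c1ncn2/C=C1/CC1(CO)CO`) also reads "not determined" (no result reported) in this assay and adds nothing. Compound 2 (`CCOc1nc(N)nc2c1ncn2/C=C1/CC1(CO)CO`) shows > 20000 nM in this assay and this entry is a limit, not a number. The compound to be tested is compound 4 (`CSc1nc(N)nc2c1ncn2/C=C1/CC1(CO)CO`). The change (methylsulfanyl in place of pyrrolidin-1-yl on an aromatic carbon) puts methylsulfanyl in place of pyrrolidin-1-yl on an aromatic carbon. Going by the values given here, no measured step covers this change, so the expectation in this assay rests only on the limit seen for compound 2 (> 20000 nM). The estimated value for compound 4 is 20000 nM (expected range 8000 nM to 50000 nM).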

Compound 4, half-maximal cytotoxic concentration: > 20000 nM
Compound 4 gave a limit, no number; the forecaster's own chance of this, stated with the estimate: 65%; the middle value lies on the limit itself.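

In this assay compound 2 gives > 20000 nM, a limit. Going by these compounds alone, compound 4 gives > 20000 nM, also a limit, so no step between compound 2 and compound 4 can be read. The compounds shown leave open how methylsulfanyl compares with ethoxy or pyrrolidin-1-yl in this read-out.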